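Ethyl for hydrogen on the coumarin carbon of compound 3

The source may report more compounds than this note shows. Statements on the series, on what has been measured and on what is new or still open speak of the compounds shown alone.

Measured compounds:
compound 1 `Cc1ccc(Nc2nc(N)nc(COc3ccc4c(C)cc(=O)oc4c3)n2)cc1`: 1790 nM
compound 2 `Cc1cc(=O)oc2cc(OCc3nc(N)nc(Nc4ccc(C5CC5)cc4)n3)ccc12`: 700 nM
compound 3 `Cc1ccc(Nc2nc(N)nc(COc3ccc4ccc(=O)oc4c3)n2)cc1`: 1280 nM

In an assay on COS-7 cells for agonist activity at Free fatty acid receptor 1 (Homo sapiens), read by scintillation counting and inositol phosphate accumulation, with a stated time of 90 min (on this read-out lower numbers stand for an effect already at smaller amounts and higher numbers for an effect only at larger amounts of compound), compound 3 gives 1280 nM, the second highest of the three numbers. Its nearest neighbour is compound 1; the two differ only within the scatter, and the same holds for the gap to compound 2, so no order among the three can be claimed.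

Compound 4 `CCc1cc(=O)oc2cc(OCc3nc(N)nc(Nc4ccc(C)cc4)n3)ccc12` has not been measured. It differs from compound 3 by ethyl in place of hydrogen on an aromatic carbon, at the aromatic carbon opposite the ring oxygen. Within the data shown here, the one step that bears on this is a 1.4-fold lower number from compound 1 to compound 3 (0.15 log units; within the scatter), which runs the other way at the same carbon and stays within the scatter. That step, read in reverse, gives a small rise when a methyl occupies this carbon; an ethyl there is expected to behave much alike. Compound 4 is therefore expected to show a 1.3-fold higher number from compound 3 to compound 4 (0.10 log units; within the scatter), a change not beyond the scatter. The estimate for compound 4 in this assay is 1600 nM, with a range from 700 nM to 3600 nM.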

Compound 4, half-maximal effective concentration: 2640 nM
Beside the measured number, compound 4's estimate is 1.7-fold (0.22 log units) below it; low and high end bracket the measured number.
By their numbers in this assay, from the lowest: compounds 2, 3, 1 and 4 (each within the scatter of the next, the first and the last beyond it).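

In this assay, among these compounds, ethyl in place of hydrogen on the aromatic carbon opposite the ring oxygen gives a 2.1-fold higher number from compound 3 to compound 4 (0.31 log units; beyond the scatter), the first change at this carbon that lies beyond the scatter, whereas the earlier step there, a 1.4-fold lower number from compound 1 to compound 3 (0.15 log units; within the scatter), stayed within it. Adding one carbon to the methyl at this position gives a 1.5-fold higher number from compound 1 to compound 4 (0.17 log units; within the scatter), so ethyl and methyl cannot be told apart here, and only ethyl is separated from hydrogen. Nothing available explains this difference.

The compounds shown leave open whether a propyl chain at this carbon would give a higher number still, and how an amine or a carboxylic acid would behave there. They also leave open whether the cyclopropyl of compound 2 would keep its step with ethyl at this carbon.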